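Urea to Amide Swap on a Pyrazole Scaffold

The source may hold more compounds than are shown below. What is called first, only, known or untested is meant among the compounds shown, and "the series" means these compounds.

Measured so far:
compound 1 `COc1cc(-c2nn(-c3cccc(NC(=O)Nc4ccc(Cl)c(Cl)c4)c3)cc2-c2ccncc2)ccc1Cl` gives 937 nM in a functional assay on COLO 205 cells (Homo sapiens) for inhibition, read by sulforhodamine B assay, with a stated time of 48 h; a higher number here means a weaker inhibitor of growth, a lower number a stronger inhibitor of growth
compound 2 `O=C(Nc1cccc(-n2cc(-c3ccncc3)c(-c3ccc(Cl)c(O)c3)n2)c1)Nc1ccc(Cl)c(Cl)c1` gives 3960 nM in this assay

Among the measured compounds shown here, compound 1 gives the lowest of the two numbers, and the only measured step, a 4.2-fold higher number from compound 1 to compound 2 (0.63 log units; beyond the scatter), concerns a change elsewhere on the core. Compound 3 `COc1cc(-c2nn(-c3cccc(NC(=O)c4ccc(Cl)c(C(F)(F)F)c4)c3)cc2-c2ccncc2)ccc1Cl` carries a different change: 4-chloro-3-(trifluoromethyl)phenyl in place of (3,4-dichlorophenyl)amino on a carbonyl carbon. For the measured compounds named here, no measured step touches this part of the molecule, so nothing here tells how large a step to expect, in either direction, in this assay. For compound 3 the number is therefore estimated near that of compound 1, at 900 nM with a range of 250 nM to 3500 nM, which is expected to mean a 1.0-fold lower number from compound 1 to compound 3 (0.02 log units; within the scatter).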

Compound 3, concentration for 50% growth inhibition: 6140 nM
Beside the measured number, compound 3's estimate is 6.8-fold (0.83 log units) below it; measured number above the stated range.
By their numbers in this assay, from the lowest: compound 1; then compounds 2 and 3 (each within the scatter of the next).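

This position on the carbonyl carbon is sensitive in this assay: putting 4-chloro-3-(trifluoromethyl)phenyl in place of (3,4-dichlorophenyl)amino gives a 6.6-fold higher number from compound 1 to compound 3 (0.82 log units; beyond the scatter). The swap removes the amino nitrogen with its hydrogen-bond donor and alters the ring's substituents in one step, so this single comparison cannot separate the two changes. Nothing measured here gives a reason for the step.

Still open is which change matters. (4-Chloro-3-(trifluoromethyl)phenyl)amino on the same carbonyl carbon would keep the nitrogen while changing only the ring, and the compounds shown do not settle this.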